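The compounds below may be only part of what the source reports. "The series", "measured", "known", "first", "only" and "open" are said of these compounds alone.

In a functional assay on PC-3 cells (Homo sapiens) for cytotoxicity, read by MTT assay, with a stated time of 72 h (a lower number here means a stronger inhibitor, a higher number a weaker inhibitor), compound 1 `COc1cc(Nc2nc3ccccc3nc2S(=O)(=O)c2ccccc2)cc(OC)c1` gives 140 nM, compound 2 `COc1cc(Nc2nc3ccccc3nc2S(=O)(=O)c2ccc(C)cc2)cc(OC)c1` gives 2940 nM, and compound 3 `COc1ccc(S(=O)(=O)c2nc3ccccc3nc2Nc2cc(OC)cc(OC)c2)cc1` gives 6220 nM. Compound 3 thus stands highest of the three, with a 2.1-fold higher number from compound 2 to compound 3 (0.33 log units; beyond the scatter) and a 44-fold higher number from compound 1 to compound 3 (1.65 log units; beyond the scatter). Compound 4 `COc1ccc(S(=O)(=O)c2nc3ccccc3nc2Nc2ccc(Cl)cc2)cc1` differs from compound 3 by 4-chlorophenyl in place of 3,5-dimethoxyphenyl on a nitrogen on an aromatic ring. Among the compounds with values here, the measured steps, a 21-fold higher number from compound 1 to compound 2 (1.32 log units; beyond the scatter) and a 44-fold higher number from compound 1 to compound 3 (1.65 log units; beyond the scatter), all change the ring attached to the sulfonyl group, not the ring on the nitrogen, so no step bears directly on this change. With nothing to guide the direction, he expects a 1.2-fold lower number from compound 3 to compound 4 (0.09 log units; within the scatter), a step that may fall within the scatter. He estimates that compound 4 gives 5000 nM in this assay, with a range from 800 nM to 30000 nM.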

Compound 4, half-maximal inhibitory concentration: 31800 nM
Compound 4: the middle estimate sits 6.4-fold (0.80 log units) below what was measured; measured number outside the range, above it.
By their numbers in this assay, from the lowest: compound 1; then compound 2; then compound 3; then compound 4.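

The ring on the nitrogen also moves the number in this assay: with the sulfonyl side held fixed, 4-chlorophenyl in place of 3,5-dimethoxyphenyl gives a 5.1-fold higher number from compound 3 to compound 4 (0.71 log units; beyond the scatter). Within the data shown here, earlier steps changed only the ring on the sulfonyl group, so this is the first view of this position, and the number rises here as well. Nothing at hand accounts for this step. As far as these compounds go, whether the same change would give a similar step on the unsubstituted sulfonyl ring of compound 1 stays open. So does how a ring on this nitrogen carrying an amine or a carboxylic acid would read.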